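Lengthening a Saturated Chain on the Shared Core

This account rests on a few compounds, and the source may have more. Where it says the series, first, only, none or still open, it means among the compounds named here.

Compound 1 `CN1CCC(COC(c2ccccc2)c2ccccc2)CC1`: > 20000 nM, a limit of the assay
Compound 2 `Clc1ccc(CCCN2CCC(COC(c3ccccc3)c3ccccc3)CC2)cc1`: 500 nM
Compound 3 `CCCCCN1CCC(COC(c2ccccc2)c2ccccc2)CC1`: 10800 nM

In a functional assay on cells (T-cell line, Homo sapiens) for inhibition (a higher number here means a weaker inhibitor, a lower number a stronger inhibitor), compound 3 gives 10800 nM, the higher of the two exact numbers, with a 22-fold higher number from compound 2 to compound 3 (1.33 log units; beyond the scatter). Compound 4 `CCCCCCN1CCC(COC(c2ccccc2)c2ccccc2)CC1` carries methyl in place of hydrogen on a saturated chain carbon, five bonds along the chain from an amine nitrogen in a ring. For the measured compounds named here, the nearest precedent is the plain-chain step, an at least 1.8-fold lower number from compound 1 to compound 3 (0.26 log units; that floor lies within the scatter). The large at least 40-fold lower number from compound 1 to compound 2 (1.60 log units; beyond the scatter) brought in 2-(4-chlorophenyl)ethyl instead, so it bears less directly. Only a small shift toward a lower number, probably within the scatter, is expected: a 1.4-fold lower number from compound 3 to compound 4 (0.13 log units; within the scatter). For compound 4 the estimated value is 8000 nM, with an expected range of 3500 nM to 18000 nM.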

Compound 4, half-maximal inhibitory concentration: 5500 nM
For compound 4 the middle estimate is 1.5-fold (0.16 log units) above the measured one, and the stated range covers the measured number.
By their numbers in this assay, from the lowest: compound 2; then compounds 4 and 3 (each within the scatter of the next). At a limit, above all of these: compound 1.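

In this assay, methyl in place of hydrogen at this place, five bonds along the chain from an amine nitrogen in a ring, gives a 2.0-fold lower number from compound 3 to compound 4 (0.29 log units; within the scatter). Pentyl in place of hydrogen gives an at least 3.6-fold lower number from compound 1 to compound 4 (0.56 log units; beyond the scatter), the first plain-chain step beyond the scatter, yet the 4-chlorophenyl group keeps its lead, with an 11-fold higher number from compound 2 to compound 4 (1.04 log units; beyond the scatter). The value of compound 1 is a limit, so that first step is only a floor: the limit of > 20000 nM in this assay, at which 1 of the 4 values shown sits.

Going by these compounds, whether a longer chain continues this trend remains open. So does whether an unsubstituted phenyl in place of 4-chlorophenyl would hold the lower number.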